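Propargylsulfanyl in place of benzylsulfanyl on the shared core

The compounds below may be only part of what the source reports. "The series", "measured", "known", "first", "only" and "open" are said of these compounds alone.

For the measured compounds named here, compound 2 `O=C(/C=C/c1cccc(Br)n1)c1ccc(Nc2cc(-c3ccccc3)nc3nc(SCc4ccccc4)nn23)cc1` gives 38.3% in a functional assay on MGC-803 cells (Homo sapiens) for inhibition, read by sulforhodamine B assay, with a stated time of 72 h, tested at 10 uM (on this read-out lower numbers stand for less inhibition and higher numbers for more inhibition at the one concentration tested (going by the name of the read-out)), the lowest of the two numbers measured so far. Going by the values given here, compound 1 `CCc1cc(Nc2ccc(C(=O)/C=C/c3cccc(Br)n3)cc2)n2nc(SCc3ccccc3)nc2n1` gives 63% in this assay; the one measured step is a number 24.7 percentage points lower from compound 1 to compound 2 (beyond the scatter). Compound 3 `C#CCSc1nc2nc(-c3ccccc3)cc(Nc3ccc(C(=O)/C=C/c4cccc(Br)n4)cc3)n2n1` differs from compound 2 in one place: ethynyl in place of phenyl on a saturated chain carbon bound to a sulfur. Among the compounds with values here, the measured step concerns an aromatic carbon, not the saturated chain carbon bound to a sulfur, so no measured step bears directly on the change from compound 2 to compound 3, and the series gives no step of any size at this place. With nothing pointing either way, the step of a number 0.3 percentage points lower from compound 2 to compound 3 (within the scatter) is expected to stay within the scatter. Within the data shown here, compound 3 is estimated at 38% in this assay, with a range from 18% to 58%, the width reflecting that no measured compound carries a propargylsulfanyl group.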

Compound 3, a percentage reported as inhibition, at one concentration (the size of the read-out at that concentration, not a potency): 56.3%
The estimate for compound 3 lay 18.3 percentage points below the measured number; low and high end bracket the measured number.
By their numbers in this assay, from the lowest: compound 2; then compounds 3 and 1 (each within the scatter of the next).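

In this assay, for the compounds shown here, propargylsulfanyl in place of benzylsulfanyl gives a number 18 percentage points higher from compound 2 to compound 3 (beyond the scatter), the first measured step on the saturated chain carbon bound to a sulfur. This place therefore responds to substitution when phenyl sits on the aromatic carbon, so the series now has a step beyond the scatter at each of two places. Nothing at hand gives a reason for this step.

Going by these compounds alone, the single pair removes a six-membered aromatic ring and brings in a triple bond at once, so it cannot show which of the two matters; an allyl group or a plain butyl chain on the sulfur would separate them. Also open, from the compounds shown here alone, is whether the same change gives a similar step when ethyl replaces phenyl on the aromatic carbon.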